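The source may report more compounds than this note shows. Statements on the series, on what has been measured and on what is new or still open speak of the compounds shown alone.

Measured compounds:
compound 1, `CNC(=O)c1ccc(-c2cnc3cnc(C(=O)N(C)c4ccc(C#N)cc4)cn23)cc1`, giving 34 mL/min/kg in an ADME assay on the whole organism for pharmacokinetics, with Mus musculus as the target, at a dose of 5 mg/kg by the intravenous route; on this read-out lower numbers stand for slow clearance and higher numbers for fast clearance
compound 2, `CN(C(=O)c1cn2c(-c3ccc(C(N)=O)cc3)cnc2cn1)c1ccc(F)cc1`, giving 39.7 mL/min/kg in this assay

Compound 1 and compound 2 share the same core and give numbers in this assay that lie within the usual scatter of each other, so the two cannot be told apart: neither can be called the faster or the slower cleared. Going by the values given here, compound 1 thus stands at a mid-range rate on the only two numbers at hand.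

Compound 3, `CN(C(=O)c1cn2c(-c3ccc(-c4nnc(N)s4)cc3)cnc2cn1)c1ccc(C#N)cc1`, has not yet been measured in this assay. It differs from compound 1 in one place: 5-amino-1,3,4-thiadiazol-2-yl in place of methylcarbamoyl on an aromatic carbon. Among the compounds with values here, no pair of measured compounds shows what such a change does to clearance, so there is no measured step to lean on. With only the two numbers from compound 1 and compound 2, both close together, the plainest expectation is a step from compound 1 to compound 3 in this assay of no size beyond the scatter, in no firm direction, that is a 1.1-fold higher number from compound 1 to compound 3 (0.05 log units; within the scatter). Compound 3 is therefore expected to give about 38 mL/min/kg in this assay, with a range from 20 mL/min/kg to 70 mL/min/kg.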

Compound 3, clearance: 16.2 mL/min/kg
Compound 3: the middle estimate sits 2.3-fold (0.37 log units) above what was measured, outside the stated range (below it).
By their numbers in this assay, from the lowest: compound 3; then compounds 1 and 2 (each within the scatter of the next).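

Placing 5-amino-1,3,4-thiadiazol-2-yl in place of methylcarbamoyl, on the six-membered aromatic ring of carbon only and para to a large group, gives in this assay a 2.1-fold lower number from compound 1 to compound 3 (0.32 log units; beyond the scatter) and so shows that clearance in the mouse responds to what stands at this position, though the step is modest. The change swaps an open group for a five-membered aromatic ring with 3 hetero atoms, keeps 1 hydrogen-bond donor, and raises the hydrogen-bond acceptors from 1 to 4, so several things alter at once and this single step cannot separate them. No measurement on these compounds says why the number falls, and this remains a plain observation.

Still open, as far as these compounds go, is whether the ring or its amine carries the step, which a carboxylic acid, a simple primary amine or the same ring without its amine at this position could help to sort out. Also open, from the compounds shown here alone, is whether the same swap would lower the number on a compound with another group on the far side of the core, such as the fluorine-bearing ring of compound 2.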